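This account rests on a few compounds, and the source may have more. Where it says the series, first, only, none or still open, it means among the compounds named here.

Working notes on the carbamate series. Compound 1 `CC1(COC(=O)N2CC3COCC(C2)C3Oc2ncnc(Nc3ccc(C#N)cc3Cl)c2F)COC1` carries a (3-methyloxetan-3-yl)methyl ester; in a functional assay for agonist activity at Glucose-dependent insulinotropic receptor (Mus musculus), read by cAMP accumulation (on this read-out lower numbers stand for an effect already at smaller amounts and higher numbers for an effect only at larger amounts of compound), compound 1 gives 516 nM. Compound 2 `CC1(OC(=O)N2CC3COCC(C2)C3Oc2ncnc(Nc3ccc(C#N)cc3Cl)c2F)CCC1` replaces that group with 1-methylcyclobutyl, and in this assay compound 2 gives 60 nM. Compound 3 `CCC1(OC(=O)N2CC3COCC(C2)C3Oc2ncnc(Nc3ccc(C#N)cc3F)c2F)CC1`, a 1-ethylcyclobutyl ester with fluorine on the aniline ring in place of chlorine, gives 43 nM in this assay. Within the three measured values, compound 2 stands second highest: its gap to compound 3 is within the scatter, while its gap to compound 1 is beyond it.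

Among the measured compounds shown here, the one measured single-point step is an 8.6-fold lower number from compound 1 to compound 2 (0.93 log units; beyond the scatter), a modest move for a change on the ester side of the carbamate.

Compound 4 `N#Cc1ccc(Nc2ncnc(OC3C4COCC3CN(C(=O)OC3CCC3)C4)c2F)c(Cl)c1` differs from compound 2 in one place: hydrogen in place of methyl on a saturated ring carbon. For the measured compounds named here, no measured pair in the set removes a single carbon from the ester group, so this change is not directly sampled. The nearest information is that the ester group in compound 2 and compound 3 yields values within the scatter of each other, which suggests the size of a small saturated ester group is not sharply read here. A change of no more than a modest size, if any, is therefore expected in this assay, and for compound 4 the expected step is a 1.8-fold higher number from compound 2 to compound 4 (0.26 log units; within the scatter), with compound 4 estimated at 110 nM and a range from 40 nM to 320 nM.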

Compound 4, half-maximal effective concentration: 60 nM
Compound 4: middle estimate off by 1.8-fold (0.26 log units), on the high side; the measured number falls inside the stated range.
By their numbers in this assay, from the lowest: compounds 3, 2 and 4 (each within the scatter of the next); then compound 1.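

In this assay, the methyl on the saturated ring carbon of the four-membered ring turns out to be dispensable, with no change at the digits printed from compound 2 to compound 4 (within the scatter): 1-methylcyclobutyl and cyclobutyl cannot be told apart on this read-out. The larger gain seen earlier on leaving the (3-methyloxetan-3-yl)methyl ester therefore does not depend on that methyl, since cyclobutyl alone gives an 8.6-fold lower number from compound 1 to compound 4 (0.93 log units; beyond the scatter), the same size of step as the one to the methylated ester, an 8.6-fold lower number from compound 1 to compound 2 (0.93 log units; beyond the scatter). No measurement among the data at hand offers an explanation for either result.

The (3-methyloxetan-3-yl)methyl and cyclobutyl groups differ in several features at once, so the compounds shown do not say which of them carries the step; a cyclobutylmethyl or an oxetan-3-yl ester on the same core would separate them. On these data alone, it also stays open how far the ester tolerates other groups on this ring carbon or in place of this ring, such as a hydroxyl, a methoxy, a cyclopropyl ring or an open isopropyl chain.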